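The compounds below may be only part of what the source reports. "The series", "measured", "known", "first", "only" and "open" are said of these compounds alone.

Measured so far:
- compound 1, `O=C1/C(=C/c2ccccc2F)Cc2ccccc21`: 150000 nM
- compound 2, `Cc1ccccc1/C=C1\CCc2ccccc2C1=O`: 50200 nM
- compound 3, `O=C1/C(=C/c2ccc(Cl)cc2Cl)Cc2ccccc21`: > 500000 nM

In a functional assay on L1210 cells (Mus musculus) for inhibition (on this read-out lower numbers stand for stronger inhibition and higher numbers for weaker inhibition), compound 1 gives 150000 nM, the highest of the two numbers recorded, with compound 2 the nearest at 50200 nM, a gap that lies beyond the scatter. For compound 3 this assay returns only a limit, > 500000 nM, not a number; this is the limit of > 500000 nM in this assay, at which 1 of the 3 values shown sits.

The next compound, compound 4, `Cc1ccccc1/C=C1\Cc2ccccc2C1=O`, keeps the core of compound 1 and changes one place: methyl in place of fluoro on an aromatic carbon, on an aromatic carbon of a six-membered aromatic ring of carbon only, ortho to a large group. Going by the values given here, no measured pair in this assay differs by exactly this change, so the size of the step has to be estimated. Compound 2 carries the same methyl on a different core and gives 50200 nM, a number well under that of compound 1. Compound 3, with two chloro groups on the same core as compound 1, has only a limit in this assay, not a number. On that basis the step from compound 1 to compound 4 is expected to be modest and towards a lower number, a 1.9-fold lower number from compound 1 to compound 4 (0.27 log units; within the scatter), though a result within the scatter would not surprise. For compound 4 in this assay the estimate is 80000 nM, expected to fall between 30000 nM and 250000 nM.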

Compound 4, half-maximal inhibitory concentration: 208000 nM
The estimate for compound 4 lay 2.6-fold (0.41 log units) below the measured number, within the range that was stated.
By their numbers in this assay, from the lowest: compound 2; then compounds 1 and 4 (each within the scatter of the next). At a limit, above all of these: compound 3.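

Methyl in place of fluoro on an aromatic carbon gives a 1.4-fold higher number from compound 1 to compound 4 (0.14 log units; within the scatter) in this assay, the first direct reading of a change at this position, on an aromatic carbon of a six-membered aromatic ring of carbon only, ortho to a large group. On the shared core, this read-out therefore does not tell the two groups apart, and the number for compound 2, 50200 nM, which carries the same methyl on a different core, cannot be carried over to methyl on the core of compound 1. No measurement shown here speaks to why the exchange of these two single-atom groups leaves the number within the scatter.

For compound 3, the value of > 500000 nM is a limit and not a number, so the two chloro groups on the core of compound 1 cannot be sized as a step. Still open, from the compounds shown here alone, is whether a group of another kind at this same position, such as an amine, a carboxylic acid or a longer chain, would move the number beyond the scatter.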